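A few compounds are considered here, and "the series" means these few. Any claim that something is new, unique, unknown or untested is made for them only; others in the source may bear on it.

Working notes on the series

Compound 1 `CN(C)C(=O)c1cc2cnc(Nc3ccc(S(=O)(=O)NCCCCN=C=S)cc3)nc2n1C1CCCC1` is the reference point. In a functional assay on A549 cells (Homo sapiens) for inhibition, read by CCK-8 assay, with a stated time of 72 h, tested at 10 uM (a higher number here means a stronger effect of the compound at the concentration tested, a lower number a weaker effect), compound 1 gives 101%, which is the full effect the read-out can show at this concentration. Within the data shown here, compound 2 `CN(C)C(=O)c1cc2cnc(Nc3ccc(S(=O)(=O)NCCCCCCCN=C=S)cc3)nc2n1C1CCCC1` is its one measured neighbour; in this assay compound 2 gives 101%, and the step of no change at the digits printed from compound 1 to compound 2 (within the scatter) is the only measured comparison available. So compound 1 stands level with compound 2, and the one change tried so far, on the chain beyond the sulfonamide nitrogen, leaves the read-out unmoved.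

Compound 3 `CN(C)C(=O)c1cc2cnc(Nc3ccc(NC(=O)CCCCCN=C=S)cc3)nc2n1C1CCCC1` is not yet measured. It differs from compound 1 by a group of 11 heavy atoms (7 carbon, 2 nitrogen, 1 oxygen, 1 sulfur; no ring) in place of a group of 11 heavy atoms (5 carbon, 2 nitrogen, 2 oxygen, 2 sulfur; no ring), on an aromatic carbon. Among the measured compounds shown here, no measured step touches this part of the molecule: the step from compound 1 to compound 2 alters the chain length only, not the group that joins the chain to the aromatic ring. The expectation rests on the read-out already sitting at its ceiling for both measured compounds, which leaves little room to rise and no evidence for a fall. Compound 3 is therefore expected to give 97% in this assay, within 82% to 104%, an expected step of a number 4 percentage points lower from compound 1 to compound 3 (within the scatter) from compound 1, that is none beyond the scatter.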

Compound 3, a percentage reported as inhibition, at one concentration (the size of the read-out at that concentration, not a potency): 100%
Compound 3: the middle estimate sits 3 percentage points below what was measured; the range from low to high includes it.
By their numbers in this assay, from the lowest: compounds 3, 1 and 2 (each within the scatter of the next).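

Among these compounds, the step of a number 1 percentage points lower from compound 1 to compound 3 (within the scatter) in this assay is the first measured change to the group on the aromatic carbon, para to a large group, and not only to the length of the chain. It shows that a sulfonamide-linked chain can give way to an amide-linked chain ending in the same isothiocyanate without the read-out leaving the scatter, so this position accepts a change of linking group as well as the change of chain length seen earlier. With all three compounds at or close to the full effect the read-out can show, the result supports tolerance of this change at the one concentration tested but gives no ranking of the two linking groups, and nothing available bears on why the read-out holds.

The compounds shown leave open what a chain ending in an amine or a carboxylic acid would give in place of the isothiocyanate that all three carry. They also leave open how compounds 1, 2 and 3 would compare at a concentration where the read-out falls short of its full effect.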